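Substituent change on the aromatic ring of compound 3

The source may hold more compounds than are shown below. What is called first, only, known or untested is meant among the compounds shown, and "the series" means these compounds.

Measured so far:
compound 1 `O=C(Nc1ccccc1)c1cc2ccccc2oc1=O`: 13100 nM
compound 2 `Cc1cccc(NC(=O)c2cc3ccccc3oc2=O)c1`: 14500 nM
compound 3 `CC(C)c1ccc(NC(=O)c2cc3ccccc3oc2=O)cc1`: 15100 nM

In an in vitro assay on BTI-TN-5B1-4 cells for inhibition of Amine oxidase [flavin-containing] A (Homo sapiens), read by fluorescence (on this read-out higher numbers stand for weaker inhibition and lower numbers for stronger inhibition), compound 1 gives 13100 nM, compound 2 gives 14500 nM and compound 3 gives 15100 nM. Compound 3 holds the highest of the three numbers, but its gaps to the other two are within the scatter, so the three compounds cannot be separated on these data.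

The next compound, compound 4 `CSc1ccc(NC(=O)c2cc3ccccc3oc2=O)cc1`, differs from compound 3 in one place: methylsulfanyl in place of isopropyl on an aromatic carbon.

For the measured compounds named here, two measured steps bear on this position. The step of a 1.1-fold higher number from compound 1 to compound 2 (0.04 log units; within the scatter) and the step of a 1.2-fold higher number from compound 1 to compound 3 (0.06 log units; within the scatter) both put a hydrocarbon group on the ring and both stayed within the scatter. Neither of these introduces a sulfur-containing group or a hydrogen-bond acceptor, so the data say nothing direct about methylsulfanyl. With no step beyond the scatter seen for changes at this place, the expectation for a 1.1-fold lower number from compound 3 to compound 4 (0.03 log units; within the scatter) is no step beyond the scatter, in either direction.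

Going by the values given here, compound 4 is therefore estimated at 14000 nM in this assay, with a range from 6000 nM to 33000 nM; the estimate is widened because only two steps, both within the scatter, inform this position.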

Compound 4, half-maximal inhibitory concentration: 14800 nM
The estimate for compound 4 lay 1.1-fold (0.02 log units) below the measured number; measured number inside the range.
By their numbers in this assay, from the lowest: compounds 1, 2, 4 and 3 (each within the scatter of the next).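

In this assay, replacing isopropyl with methylsulfanyl brings a sulfur-containing group with a hydrogen-bond acceptor onto the aromatic carbon para to a large group, and it gives a 1.0-fold lower number from compound 3 to compound 4 (0.01 log units; within the scatter). Set against the unsubstituted ring, the same group gives a 1.1-fold higher number from compound 1 to compound 4 (0.05 log units; within the scatter), so both new steps stay within the scatter and the position is no longer tested with hydrocarbon groups alone: at this carbon, neither the change in atom type nor the added acceptor separates compound 4 from compound 1 or compound 3. Nothing available on the series accounts for this flat result.

Still open, going by these compounds, is whether an amine, a carboxylic acid, a halogen such as chlorine or a longer alkyl chain at this carbon would give a step beyond the scatter, or whether such a step is possible at this position at all. Equally open is whether a change to the shared core or to the amide linking it to the aromatic ring would move the number further than any change to a ring substituent shown here.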